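Chloro in Place of Methyl: Compound 2 to Compound 3

The source may hold more compounds than are shown below. What is called first, only, known or untested is meant among the compounds shown, and "the series" means these compounds.

Among the measured compounds shown here, compound 2 `CCOC(=O)c1c(-c2ccc(Cl)cc2)cc(-c2ccccc2)nc1Nc1ccc(C)cc1` sits at the top of the two numbers measured so far in a functional assay on the whole organism (strain Wister albino) for inhibition, with Rattus norvegicus as the target, read by paw edema, with stated times of 1 h and 2 h, at a dose of 50 mg/kg by the intraperitoneal route (a higher number here means more inhibition at the dose given (going by the name of the read-out), a lower number less inhibition), where compound 2 gives 32.6%; the gap to compound 1 `CCOC(=O)c1c(-c2ccc(Cl)cc2)cc(-c2ccccc2)nc1N1CCCCC1`, which gives 29.1%, is within the scatter, as the step of a number 3.5 percentage points higher from compound 1 to compound 2 (within the scatter) shows. Compound 3 `CCOC(=O)c1c(-c2ccc(Cl)cc2)cc(-c2ccccc2)nc1Nc1ccc(Cl)cc1` differs from compound 2 by chloro in place of methyl on an aromatic carbon. For the measured compounds named here, the only measured step, a number 3.5 percentage points higher from compound 1 to compound 2 (within the scatter), concerns another exchange and offers no guide to this one. A step within the scatter, a number 0.4 percentage points higher from compound 2 to compound 3 (within the scatter), is therefore expected. Compound 3 is estimated at 33%, between 22% and 44%.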

Compound 3, a percentage reported as inhibition, in the whole organism at one dose (the size of the read-out at that dose, not a potency): 40.6%
Estimate against measurement, compound 3: 7.6 percentage points below, and the stated range covers the measured number.
By their numbers in this assay, from the lowest: compounds 1, 2 and 3 (each within the scatter of the next, the first and the last beyond it).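

In this assay, chloro in place of methyl on this aromatic carbon gives a number 8 percentage points higher from compound 2 to compound 3 (within the scatter), so this exchange alone cannot be told apart from the scatter. The change from piperidin-1-yl to (4-chlorophenyl)amino gives a number 11.5 percentage points higher from compound 1 to compound 3 (beyond the scatter), the first modest separation in the series, whereas the same change to (4-methylphenyl)amino stayed within the scatter. Nothing available explains this difference.

On these data alone, what fluoro or methoxy on the same aromatic carbon would give remains open. So does whether a morpholin-4-yl group would match piperidin-1-yl.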